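Fluoro in place of chloro: a small expected step

The source may hold more compounds than are shown below. What is called first, only, known or untested is meant among the compounds shown, and "the series" means these compounds.

compound 1 `O=C1NC(=S)/C(=C/c2ccc(Cl)cc2)S1` gives 3.91%
compound 2 `O=C1NC(=S)/C(=C/c2ccccc2Br)S1` gives 10.3%
compound 3 `O=C1NC(=S)/C(=C/c2cccc(Cl)c2)S1` gives 5.44%

In a functional assay on HEp-2 cells (Homo sapiens) for cytotoxicity, read by MTT assay, with a stated time of 72 h, tested at 2.5 ug/mL (on this read-out higher numbers stand for more inhibition of growth at the one concentration tested and lower numbers for less inhibition of growth), compound 1 gives 3.91% and so sits within the usual scatter of compound 3 (5.44%) and compound 2 (10.3%). These three numbers cannot be ranked. Compound 4 `O=C1NC(=S)/C(=C/c2ccc(F)cc2)S1` has fluoro in place of chloro on an aromatic carbon and is still unmeasured. Among the compounds with values here, no measured pair differs in one place only, so the data offer no direct guide. With compound 3 at 5.44% as the nearest neighbour of compound 1, no step beyond the scatter is expected in this assay and the estimated a number 2.1 percentage points higher from compound 1 to compound 4 (within the scatter) stays small. Compound 4 is estimated at 6% (from 0% to 15%).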

Compound 4, percent growth inhibition at one concentration: -4.51%
Compound 4: the middle estimate sits 10.5 percentage points above what was measured, outside the stated range (below it).
By their numbers in this assay, from the lowest: compounds 4, 1, 3 and 2 (each within the scatter of the next, the first and the last beyond it).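

In this assay, within the data shown here, the swap of chloro for fluoro on the aromatic carbon gives the first comparison that differs in one place only: a number 8.4 percentage points lower from compound 1 to compound 4 (within the scatter). At this position, therefore, the two halogens leave compound 1 and compound 4 indistinguishable on this read-out. No supporting measurement is available to explain this result.

Going by these compounds, whether an amine or a carboxylic acid on the same aromatic carbon would give a step beyond the scatter remains open. So does whether a methoxy group there would do so.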